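A few compounds are considered here, and "the series" means these few. Any claim that something is new, unique, unknown or untested is made for them only; others in the source may bear on it.

Measured in a functional assay on MCF7 cells (Homo sapiens) for cytotoxicity, read by MTT assay, with a stated time of 72 h; a higher number here means a weaker inhibitor, a lower number a stronger inhibitor:
- compound 1 `COc1ccccc1/C=C1\CCC/C(=C\c2ccc(OC)c(OC)c2)C1=O`: 8000 nM
- compound 2 `COc1ccc(/C=C2\CCC/C(=C\c3ccc(Cl)cc3Cl)C2=O)cc1OC`: 16200 nM

Going by the values given here, compound 2 gives the higher number of the two, and its only neighbour on the scale is compound 1. Compound 3 `COc1ccc(/C=C2\CCC/C(=C\c3ccc(O)c(O)c3)C2=O)cc1OC` has not yet been measured. It departs from compound 2 in one place, on a double-bonded chain carbon bound to a double-bonded ring carbon: 3,4-dihydroxyphenyl in place of 2,4-dichlorophenyl on a double-bonded chain carbon bound to a double-bonded ring carbon. Among the compounds with values here, one measured step bears on this place, where 2,4-dichlorophenyl replaced 2-methoxyphenyl: a 2.0-fold higher number from compound 1 to compound 2 (0.31 log units; beyond the scatter). That step was modest. Within the data shown here, no measured compound carries 3,4-dihydroxyphenyl, so it offers only a loose guide. Losing 2,4-dichlorophenyl is therefore expected to bring a modest move to a lower number in this assay, though the uncertainty is wide. The expected change is a 2.3-fold lower number from compound 2 to compound 3 (0.36 log units; beyond the scatter). For compound 3 the estimated value is 7000 nM, with an expected range from 2000 nM to 22000 nM.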

Compound 3, half-maximal inhibitory concentration: 14400 nM
Beside the measured number, compound 3's estimate is 2.1-fold (0.31 log units) below it; low and high end bracket the measured number.
By their numbers in this assay, from the lowest: compounds 1, 3 and 2 (each within the scatter of the next, the first and the last beyond it).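

In this assay, the swap at this place, on a double-bonded chain carbon bound to a double-bonded ring carbon, gave a 1.1-fold lower number from compound 2 to compound 3 (0.05 log units; within the scatter), so exchanging 2,4-dichlorophenyl, with 0 hydrogen-bond donors and 0 hydrogen-bond acceptors, for 3,4-dihydroxyphenyl, with 2 of each, left the reading unchanged within the scatter. The comparison with 2-methoxyphenyl, a 1.8-fold higher number from compound 1 to compound 3 (0.26 log units; within the scatter), also stays within the scatter, so compound 3 cannot be separated from either earlier compound, although those two differ from each other beyond it. Nothing available explains why these groups read as they do.

The compounds shown all carry a substituted phenyl at this place, so it remains open whether an amine or a carboxylic acid there would stay in this range. Going by these compounds, it is also open whether the same insensitivity would hold with a different group in place of the 3,4-dimethoxyphenyl shared by all three.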